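The source may report more compounds than this note shows. Statements on the series, on what has been measured and on what is new or still open speak of the compounds shown alone.

Series of three measured compounds and one still pending. Compound 2 `CCOc1nc(N)nc2ncc(-c3ccc(C(F)(F)F)cc3)nc12` gives 10000 nM in a functional assay on cells (T-cell, Homo sapiens) for inhibition; on this read-out lower numbers stand for stronger inhibition and higher numbers for weaker inhibition. Compound 1 `CC(C)Oc1nc(N)nc2ncc(-c3ccc(C(F)(F)F)cc3)nc12` reaches only the limit of this assay, > 10000 nM. Compound 3 `CCOc1nc(N)nc2ncc(-c3ccc(F)c(F)c3)nc12` likewise reaches only the limit, > 10000 nM. The change from compound 2 to compound 1 is methyl in place of hydrogen on a saturated chain carbon bound to an oxygen on an aromatic ring and a saturated chain carbon, and the step it made is a number no lower from compound 2 to compound 1 (the limit leaves the size open). How the core of compound 2 differs from the core of compound 3 is not broken down here. Compound 4 `CC(C)Oc1nc(N)nc2ncc(-c3ccc(F)c(F)c3)nc12` carries the same change relative to compound 3, (methyl in place of hydrogen on a saturated chain carbon bound to an oxygen on an aromatic ring and a saturated chain carbon), at a place described in the same words. For compound 4 the expected step is a step that the limit leaves unreadable from compound 3 to compound 4, which rests on a number no lower from compound 2 to compound 1 (the limit leaves the size open) and on (the limit of > 10000 nM in this assay, at which 2 of the 3 values shown sit), where compound 3 already sits. Compound 4 is expected near 20000 nM, between 8000 nM and 60000 nM, and most likely reported only as a limit.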

Compound 4, half-maximal inhibitory concentration: 10000 nM
Beside the measured number, compound 4's estimate is 2.0-fold (0.30 log units) above it, and the stated range covers the measured number.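

In this assay compound 4 gives 10000 nM, and the ethoxy to isopropoxy change gives a number no higher from compound 3 to compound 4 (the limit leaves the size open) and the size of this step cannot be read on either core. Set side by side, the two steps neither show nor exclude that the change carries from one core to the other with the same effect: the same change on two cores in this assay, a number no lower (the limit leaves the size open) from compound 2 to compound 1 and a number no higher (the limit leaves the size open) from compound 3 to compound 4; the limit leaves it open whether they differ. The series offers little room for such a comparison, as most of its values are limits: the limit of > 10000 nM in this assay, at which 2 of the 4 values shown sit.

Still open, going by these compounds, is whether any group at this place gives a number clear of that limit. An amine or a longer chain in place of ethoxy or isopropoxy would test this in this assay.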